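From pyridin-4-yl to isopropyl on the shared core

The source may hold more compounds than are shown below. What is called first, only, known or untested is meant among the compounds shown, and "the series" means these compounds.

Measured in a toxicity assay on NIH3T3 cells (Mus musculus) for cytotoxicity, read by resazurin assay; on this read-out lower numbers stand for an effect already at smaller amounts and higher numbers for an effect only at larger amounts of compound:
compound 1 `COC(=O)c1ccc(NCc2cncn2Cc2ccccc2N)cc1-c1ccccc1`: 25000 nM
compound 2 `COC(=O)c1ccc(NCc2cncn2Cc2cccc(F)c2)cc1-c1ccccc1`: > 1000 nM
compound 3 `c1ccc(Cn2cncc2CNc2cccc(-c3ccncc3)c2)cc1`: > 1000 nM

For compound 3, > 1000 nM is a limit and not a number. Compound 2 also reports only a limit, and the two share (the limit of > 1000 nM in this assay, at which 2 of the 3 values shown sit). Compound 4 `CC(C)c1cccc(NCc2cncn2Cc2ccccc2)c1` carries isopropyl in place of pyridin-4-yl on an aromatic carbon. Going by the values given here, the only measured step, a step that the limit leaves unreadable from compound 1 to compound 2, lies at another place and gives no usable size. Among the compounds with values here, the single number, for compound 1 at 25000 nM, suggests effects only at large amounts. The expected change, a step that the limit leaves unreadable from compound 3 to compound 4, is therefore an estimate with no firm direction. In this assay, compound 4 is expected at 12000 nM, with an estimated range from 2500 nM to 50000 nM.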

Compound 4, half-maximal effective concentration: > 1000 nM
Compound 4 gave a limit, no number; the forecaster's own chance of this, stated with the estimate: 55%; the middle value lies beyond the limit too.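

In this assay, going by these compounds alone, compound 3 and compound 4 each report only a limit, so no step between them can be read: the limit of > 1000 nM in this assay, at which 3 of the 4 values shown sit. The compounds shown leave open whether isopropyl in place of pyridin-4-yl changes the read-out at all.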